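Fluoro Replaces Hydrogen on the Anilino Ring of Compound 3

The source may hold more compounds than are shown below. What is called first, only, known or untested is meant among the compounds shown, and "the series" means these compounds.

Compound 3 `O=C1C(Nc2ccccc2)=CC(=O)c2c1nc1n2[C@H]2OC[C@@H](O)[C@H]2OC1` shares its core with compound 1 `COc1cccc(NC2=CC(=O)c3c(nc4n3[C@H]3OC[C@@H](O)[C@H]3OC4)C2=O)c1` and compound 2 `O=C1C(NC2CC2)=CC(=O)c2c1nc1n2[C@H]2OC[C@@H](O)[C@H]2OC1`. In a functional assay on MCF7 cells (Homo sapiens) for inhibition, read by sulforhodamine B assay (a lower number here means a stronger inhibitor, a higher number a weaker inhibitor), compound 1 gives 3830 nM. Compound 2 reaches only a limit of this assay, > 16000 nM. Compound 3 also reaches only a limit, > 4000 nM, so its place is known merely as a floor. Among the measured steps, an at least 4.1-fold higher number from compound 1 to compound 2 (0.62 log units; beyond the scatter), whereas an at least 1.0-fold higher number from compound 1 to compound 3 (0.01 log units; that floor lies within the scatter), and a step that the two limits leave unreadable from compound 2 to compound 3. Compound 4 `O=C1C(Nc2ccccc2F)=CC(=O)c2c1nc1n2[C@H]2OC[C@@H](O)[C@H]2OC1` differs from compound 3 by fluoro in place of hydrogen on an aromatic carbon. Among the compounds with values here, no measured step trades hydrogen for fluoro, and the nearest guide, that an at least 1.0-fold higher number from compound 1 to compound 3 (0.01 log units; that floor lies within the scatter), stays within the scatter, so for compound 4 no step beyond the scatter is expected. The estimate for compound 4 is 5000 nM, within 2000 nM to 16000 nM. This is expected to read as a step that the limit leaves unreadable from compound 3 to compound 4.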

Compound 4, half-maximal inhibitory concentration: > 4000 nM
Compound 4: a limit, no number; the forecaster's own chance of this, stated with the estimate: 55%; the middle value is on the limit's open side.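

With 2-fluorophenyl on the amine nitrogen, compound 4 also ends at a limit in this assay, > 4000 nM, so fluoro on this aromatic carbon does not bring a value into readable range. Set against the 3-methoxyphenyl group, the change gives an at least 1.0-fold higher number from compound 1 to compound 4 (0.01 log units; that floor lies within the scatter). The steps from compound 2 and from compound 3 to compound 4 cannot be read, and this limit is a shared one: the limit of > 4000 nM in this assay, at which 2 of the 4 values shown sit.

On these data alone, how far compound 3 and compound 4 actually lie from each other stays open. Also open, as far as these compounds go, is whether an amine or a carboxylic acid on this ring, ortho to a large group, would give a true number.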